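The source may hold more compounds than are shown below. What is called first, only, known or untested is meant among the compounds shown, and "the series" means these compounds.

Measured compounds:
compound 1 `CCOC(=O)c1sc(-c2cccc(NC(=O)c3ccc(F)cc3)c2)nc1Nc1ccc(N2CCN(C)CC2)cc1` — "not determined" (no result reported)
compound 2 `CN1CCN(c2ccc(Nc3nc(-c4cccc(NC(=O)c5cccc(F)c5)c4)sc3C(=O)O)cc2)CC1` — 35100 nM
compound 3 `CN1CCN(c2ccc(Nc3nc(-c4cccc(NC(=O)c5ccc(F)cc5)c4)sc3C(N)=O)cc2)CC1` — 2820 nM

In a functional assay on Raji cells (Homo sapiens) for antiproliferative activity, read by CCK-8 assay, with a stated time of 72 h (on this read-out higher numbers stand for weaker inhibition and lower numbers for stronger inhibition), compound 3 gives the lowest number of the two reported, and compound 2 gives a number a full step higher, a gap that lies beyond the usual scatter; compound 1 has no result. Compound 4 `CN1CCN(c2ccc(Nc3nc(-c4cccc(NC(=O)c5ccccc5F)c4)sc3C(N)=O)cc2)CC1` keeps the whole framework of compound 3 and changes only the ring on the carbonyl carbon: 2-fluorophenyl in place of 4-fluorophenyl on a carbonyl carbon. Moving a single fluorine around an otherwise unchanged ring is a small change, and no comparable step has been measured here, so the expectation is a shift of about a 1.2-fold higher number from compound 3 to compound 4 (0.09 log units; within the scatter) in this assay, within the scatter. Compound 4 is therefore expected to give about 3500 nM, between 1200 nM and 10000 nM.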

Compound 4, half-maximal inhibitory concentration: 3270 nM
The estimate for compound 4 lay 1.1-fold (0.03 log units) above the measured number; measured number inside the range.
By their numbers in this assay, from the lowest: compounds 3 and 4 (each within the scatter of the next); then compound 2.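

Among the compounds with numbers, this is the first step that changes one place only. In this assay, 2-fluorophenyl in place of 4-fluorophenyl on a carbonyl carbon gives a 1.2-fold higher number from compound 3 to compound 4 (0.06 log units; within the scatter) so at this position, these two placements of the fluorine cannot be told apart. Nothing available explains this result.

Still open, on these data alone, is whether a plain phenyl ring on the same carbonyl carbon would stay within the scatter of these two compounds. As far as these compounds go, whether a 2-chlorophenyl, a 2-methoxyphenyl or an aminophenyl group there would move the number beyond the scatter is also open.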